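Chlorophenyl position on a furanyl-bearing pyridine core

This account rests on a few compounds, and the source may have more. Where it says the series, first, only, none or still open, it means among the compounds named here.

Three measured compounds share one core with a 4-hydroxyphenyl group, a chlorophenyl group and a five- or six-membered heteroaryl group. Compound 2 `Oc1ccc(-c2cc(-c3ccc(Cl)cc3)nc(-c3ccccn3)c2)cc1` carries 4-chlorophenyl and pyridin-2-yl; in a functional assay on DU-145 cells (Homo sapiens) for cytotoxicity, read by CCK-8 assay and cell counting, with a stated time of 2 days (on this read-out higher numbers stand for weaker inhibition and lower numbers for stronger inhibition), compound 2 gives 22500 nM. Compound 1 `Oc1ccc(-c2cc(-c3cccc(Cl)c3)nc(-c3ccccn3)c2)cc1` differs from compound 2 by 3-chlorophenyl in place of 4-chlorophenyl on an aromatic carbon, and in this assay compound 1 gives 35200 nM. The step is a 1.6-fold higher number from compound 2 to compound 1 (0.19 log units; within the scatter). Compound 3 `Oc1ccc(-c2cc(-c3ccc(Cl)cc3)nc(-c3ccco3)c2)cc1` differs from compound 2 by furan-2-yl in place of pyridin-2-yl on an aromatic carbon; in this assay compound 3 gives 7280 nM, which is a 3.1-fold lower number from compound 2 to compound 3 (0.49 log units; beyond the scatter) and the lowest number of the three.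

Compound 4 `Oc1ccc(-c2cc(-c3cccc(Cl)c3)nc(-c3ccco3)c2)cc1` is not yet measured. It differs from compound 3 by 3-chlorophenyl in place of 4-chlorophenyl on an aromatic carbon. This is the same kind of change as that from compound 2 to compound 1, not the same: around the place, compound 1 has the new group meta to a pyridin-2-yl group, whereas compound 4 has it meta to a furan-2-yl group. Among the measured compounds shown here, the only measured precedent for moving the chlorine, compound 2 to compound 1, gave a step that stayed within the scatter, so for compound 4 the expected step from compound 3 is a 1.5-fold higher number from compound 3 to compound 4 (0.18 log units; within the scatter), a small rise resting on that single precedent a 1.6-fold higher number from compound 2 to compound 1 (0.19 log units; within the scatter). For the measured compounds named here, with only one such pair, the expectation is loose. Compound 4 is estimated in this assay at 11000 nM, with a range from 5000 nM to 25000 nM.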

Compound 4, half-maximal inhibitory concentration: 5750 nM
Beside the measured number, compound 4's estimate is 1.9-fold (0.28 log units) above it; low and high end bracket the measured number.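

Replacing 4-chlorophenyl with 3-chlorophenyl on the furan-2-yl core in this assay gives a 1.3-fold lower number from compound 3 to compound 4 (0.10 log units; within the scatter), and this step does not differ from the same replacement on the pyridin-2-yl core: the same change on two cores in this assay, a 1.6-fold higher number (0.19 log units; within the scatter) from compound 2 to compound 1 and a 1.3-fold lower number (0.10 log units; within the scatter) from compound 3 to compound 4, 2.0-fold (0.30 log units) apart, within the scatter of two such steps

Furan-2-yl in place of pyridin-2-yl, with 3-chlorophenyl on the core, gives a 6.1-fold lower number from compound 1 to compound 4 (0.79 log units; beyond the scatter), a step beyond the scatter that also matches its counterpart with 4-chlorophenyl: the same change on two cores in this assay, a 3.1-fold lower number (0.49 log units; beyond the scatter) from compound 2 to compound 3 and a 6.1-fold lower number (0.79 log units; beyond the scatter) from compound 1 to compound 4, 2.0-fold (0.30 log units) apart, within the scatter of two such steps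

Within these four compounds, each change therefore carries across the two cores, with the heteroaryl swap shifting the number and the chlorine move leaving it within the scatter, but this rests on one pair of steps per change in a single cell line and shows neither a direction for the chlorine move nor transfer to any other core.

As far as these compounds go, it remains open whether the lower numbers with furan-2-yl extend to other heteroaryl groups such as thiophen-2-yl, or whether the chlorine move stays this small when bromine or trifluoromethyl replaces the chlorine. The role of the 4-hydroxyphenyl group is also open, since every compound shown carries it and none has a methoxy group or an amine in place of the hydroxyl.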